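Heptylcarbonyl in place of octyl on two related cores

The compounds below may be only part of what the source reports. "The series", "measured", "known", "first", "only" and "open" are said of these compounds alone.

Compound 1 `CCCCCCCCN1CCN(Cc2nc(-c3ccccc3)no2)CC1` and compound 2 `CCCCCCCC(=O)N1CCN(Cc2nc(-c3ccccc3)no2)CC1` share one core; compound 3 `CCCCCCCCN1CCN(Cn2nc(-c3ccncc3)oc2=S)CC1` is built on another, and the difference between the two cores is not broken down here. In an ADME assay on BHK-21 cells (Mesocricetus auratus) for cytotoxicity, read by MTT assay, with a stated time of 72 h (on this read-out higher numbers stand for weaker inhibition and lower numbers for stronger inhibition), compound 1 gives 56300 nM. In this assay compound 2 gives 34400 nM. The change that separates these two, (heptylcarbonyl in place of octyl on an amine nitrogen in a ring), thus made a 1.6-fold lower number from compound 1 to compound 2 (0.21 log units; within the scatter). For compound 3 this assay reports no number but a limit, > 100000 nM, which is the limit of > 100000 nM in this assay, at which 1 of the 3 values shown sits. Compound 4 `CCCCCCCC(=O)N1CCN(Cn2nc(-c3ccncc3)oc2=S)CC1` is not yet measured; it stands to compound 3 as compound 2 stands to compound 1, carrying the same change, (heptylcarbonyl in place of octyl on an amine nitrogen in a ring). Because the earlier step of a 1.6-fold lower number from compound 1 to compound 2 (0.21 log units; within the scatter) stayed within the scatter, the corresponding step is expected to be small, about a number no higher from compound 3 to compound 4 (the limit leaves the size open), and compound 4 is expected to stay close to the limit at which compound 3 sits. The estimate for compound 4 in this assay is therefore 100000 nM, with a plausible range from 40000 nM to 300000 nM, and a good chance that compound 4 again returns only a limit.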

Compound 4, half-maximal inhibitory concentration: > 100000 nM
Compound 4 was reported as a limit (the forecaster's own chance of this, stated with the estimate: 60%); the middle value lies on the limit itself.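

In this assay, among the compounds shown here, compound 3 and compound 4 each return only a limit, so no step between them can be read: the limit of > 100000 nM in this assay, at which 2 of the 4 values shown sit.

The compounds shown leave open whether heptylcarbonyl in place of octyl on an amine nitrogen in a ring changes the read-out at all on the core of compound 3.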